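The source may report more compounds than this note shows. Statements on the series, on what has been measured and on what is new or still open speak of the compounds shown alone.

Measured compounds:

compound 1 `CCN1CCN(c2nc(Nc3ccc(C(=O)NC4CC(C)(C)N([O])C(C)(C)C4)cc3)ncc2[N+](=O)[O-])CC1` — 56800 nM
compound 2 `CC1(C)CC(NC(=O)c2ccc(Nc3ncc([N+](=O)[O-])c(N4CCN(c5ccc(F)cc5)CC4)n3)cc2)CC(C)(C)N1[O]` — 13100 nM
compound 3 `Cc1cc(Nc2nc(Nc3ccc(C(=O)NC4CC(C)(C)N([O])C(C)(C)C4)cc3)ncc2[N+](=O)[O-])no1` — 7360 nM

All three were tested in a functional assay on HepG2 cells (Homo sapiens) for antiproliferative activity, read by MTT assay, with a stated time of 48 h; a lower number here means a stronger inhibitor, a higher number a weaker inhibitor. Compound 3 shows the lowest of the three numbers; against compound 2 the gap is within the scatter, so the two cannot be separated, while compound 1 sits clearly higher, as the step of a 7.7-fold lower number from compound 1 to compound 3 (0.89 log units; beyond the scatter) records.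

Compound 4 `CCOC(=O)c1csc(Nc2nc(Nc3ccc(C(=O)NC4CC(C)(C)N([O])C(C)(C)C4)cc3)ncc2[N+](=O)[O-])n1` differs from compound 3 in one place: 4-(ethoxycarbonyl)-1,3-thiazol-2-yl in place of 5-methyl-1,2-oxazol-3-yl on a nitrogen on an aromatic ring. Among the measured compounds shown here, no measured step exchanges one five-membered heteroaromatic ring for another at this position. The step of a 7.7-fold lower number from compound 1 to compound 3 (0.89 log units; beyond the scatter) touches the same place but replaced a 4-ethylpiperazin-1-yl group, a change of a different kind; the step of a 4.3-fold lower number from compound 1 to compound 2 (0.64 log units; beyond the scatter) lies elsewhere in the molecule. Neither gives a direct guide, so the expectation is a step within the scatter, with wide uncertainty.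

Compound 4 is therefore estimated at 7000 nM, with a range from 2500 nM to 20000 nM. The expected step is a 1.1-fold lower number from compound 3 to compound 4 (0.02 log units; within the scatter).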

Compound 4, half-maximal inhibitory concentration: 6870 nM
Compound 4: the middle estimate sits 1.0-fold (0.01 log units) above what was measured; measured number inside the range.
By their numbers in this assay, from the lowest: compounds 4, 3 and 2 (each within the scatter of the next); then compound 1.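

In this assay, the 4-(ethoxycarbonyl)-1,3-thiazol-2-yl group, with 10 heavy atoms against 6 in the 5-methyl-1,2-oxazol-3-yl group, gives a 1.1-fold lower number from compound 3 to compound 4 (0.03 log units; within the scatter), so at this nitrogen the two groups cannot be separated. Among the compounds shown here, replacing 4-ethylpiperazin-1-yl on the aromatic carbon with the (4-(ethoxycarbonyl)-1,3-thiazol-2-yl)amino group gives an 8.3-fold lower number from compound 1 to compound 4 (0.92 log units; beyond the scatter), which means that a second amino-linked five-membered aromatic ring, not only the one in compound 3, stands clear of compound 1. No measurement at hand bears on the reason for this result.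

The compounds shown leave open whether the ethoxycarbonyl group contributes at all, as a plain 1,3-thiazol-2-yl group or a carboxylic acid in its place does not appear among them. They also leave open what a six-membered aromatic ring such as phenyl would give on this nitrogen.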